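The compounds below may be only part of what the source reports. "The series", "measured", "known", "first", "only" and "open" are said of these compounds alone.

Measured compounds:
- Compound 1 `CC(=O)OCCO[C@H](CC=C(C)C)C1=CC(=O)c2c(O)ccc(O)c2C1=O`: in a functional assay on HeLa cells (Homo sapiens) for cytotoxicity, read by MTT assay (on this read-out higher numbers stand for weaker inhibition and lower numbers for stronger inhibition), compound 1 gives 41500 nM.
- Compound 2 `CC(C)=CC[C@@H](OC(=O)CC(C)(O)c1ccccc1)C1=CC(=O)c2c(O)ccc(O)c2C1=O`: compound 2 gives 85700 nM.
- Compound 3 `CC(C)=CC[C@@H](OC(=O)CCO)C1=CC(=O)c2c(O)ccc(O)c2C1=O`: compound 3 gives 67600 nM.

Compound 3 stands second highest of the three numbers; its nearest neighbour is compound 2, the furthest compound 1, and both gaps lie within the scatter, so no order among the three can be read.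

Compound 4 `CC(C)=CC[C@@H](OC(=O)CC(C)(O)C(C)C)C1=CC(=O)c2c(O)ccc(O)c2C1=O` differs from compound 3 in one place: 1-hydroxy-1,2-dimethylpropyl in place of hydroxymethyl on a saturated chain carbon bound to a carbonyl carbon.

The step that bears most directly on this is the one at the same place, where the 1-hydroxy-1-phenylethyl group of compound 2 was cut back to hydroxymethyl: a 1.3-fold lower number from compound 2 to compound 3 (0.10 log units; within the scatter). Growing the substituent at this position again, now to 1-hydroxy-1,2-dimethylpropyl, is therefore expected to move the number little. The other step, a 1.6-fold higher number from compound 1 to compound 3 (0.21 log units; within the scatter), concerns a different change and also stays within the scatter. Within the data shown here, nothing among the measured compounds points to a shift beyond the scatter in either direction.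

Compound 4 is therefore estimated at 72000 nM, with a range of 36000 nM to 145000 nM. The expected step is a 1.1-fold higher number from compound 3 to compound 4 (0.03 log units; within the scatter).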

Compound 4, half-maximal inhibitory concentration: 27700 nM
Beside the measured number, compound 4's estimate is 2.6-fold (0.41 log units) above it; the whole stated range lies above it.
By their numbers in this assay, from the lowest: compounds 4, 1, 3 and 2 (each within the scatter of the next, the first and the last beyond it).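

In this assay, 1-hydroxy-1,2-dimethylpropyl in place of hydroxymethyl on the saturated chain carbon bound to a carbonyl carbon gives (a 2.4-fold lower number from compound 3 to compound 4 (0.39 log units; beyond the scatter)), and isopropyl in place of phenyl on the same hydroxyl-bearing carbon gives (a 3.1-fold lower number from compound 2 to compound 4 (0.49 log units; beyond the scatter)), so this position does respond to the group placed there. The number does not simply follow growth of the group: the step (a 1.3-fold lower number from compound 2 to compound 3 (0.10 log units; within the scatter)) leaves 1-hydroxy-1-phenylethyl and hydroxymethyl inseparable, while 1-hydroxy-1,2-dimethylpropyl stands apart from both, although the step (a 1.5-fold lower number from compound 1 to compound 4 (0.18 log units; within the scatter)) still leaves compound 4 inseparable from the 2-acetoxyethyl ether, compound 1. No measurement at hand gives a reason for this difference.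

Still open, as far as these compounds go, is whether the isopropyl group itself carries the step, which a cyclohexyl group or a longer alkyl chain on the same carbon would test. Also open, from the compounds shown here alone, is whether the hydroxyl on that carbon matters, as an amine or a methyl ether there would show.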